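The source may hold more compounds than are shown below. What is called first, only, known or untested is meant among the compounds shown, and "the series" means these compounds.

Compound 1 `Oc1ccc(O)c(-c2cc(-c3ccc(Cl)cc3)nn2-c2ccccc2)c1` gives 17900 nM in a functional assay on cells (Cancer cell lines, Homo sapiens) for cytotoxicity, read by sulforhodamine B assay, with a stated time of 48 h; on this read-out lower numbers stand for stronger inhibition of growth and higher numbers for weaker inhibition of growth.
Compound 2 `NS(=O)(=O)c1ccc(-n2nc(-c3ccc(Cl)cc3)cc2-c2cc(O)ccc2O)cc1` gives 17800 nM in this assay.
Compound 3 `CC(=O)NS(=O)(=O)c1ccc(-n2nc(-c3ccccc3)cc2-c2cc(O)ccc2O)cc1` gives 90400 nM in this assay.

Of the three measured compounds, compound 3 stands at the highest number: compound 1 and compound 2 both lie well beyond the scatter below it, and the two of them differ from each other only within the scatter, the step of a 1.0-fold lower number from compound 1 to compound 2 (0.00 log units; within the scatter) being as small as it is. Compound 3 is thus the weakest grower-inhibitor among the measured set.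

Compound 4 `CC(=O)NS(=O)(=O)c1ccc(-n2nc(-c3ccc(Cl)cc3)cc2-c2cc(O)ccc2O)cc1` is compound 3 with one change: chloro in place of hydrogen on an aromatic carbon. For the measured compounds named here, no measured step bears directly on this change. Going by the values given here, the only measured step, from compound 1 to compound 2, concerns a sulfamoyl group on a different ring and was flat. Compound 1 and compound 2 both carry the 4-chlorophenyl group that compound 4 gains, and both sit far below compound 3. Among the compounds with values here, neither has an unsubstituted phenyl counterpart in the data, so no step that isolates the chloro change is available. The step is therefore expected to be modest, most likely downward but not clearly beyond the scatter; the estimate for compound 4 is 55000 nM (range 22000 nM to 140000 nM), meaning an expected step of a 1.6-fold lower number from compound 3 to compound 4 (0.22 log units; within the scatter).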

Compound 4, concentration for 50% growth inhibition: 38500 nM
Compound 4: middle estimate off by 1.4-fold (0.15 log units), on the high side; the measured number falls inside the stated range.
By their numbers in this assay, from the lowest: compounds 2 and 1 (each within the scatter of the next); then compound 4; then compound 3.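

In this assay, for the compounds shown here, the change from phenyl to 4-chlorophenyl, on an aromatic carbon para to a large group, can be read alone for the first time, and it gives a 2.3-fold lower number from compound 3 to compound 4 (0.37 log units; beyond the scatter) in favour of the chlorinated compound. With the chloro group held constant, the sulfonamide nitrogen can also be read: acetyl in place of the hydrogen there gives a 2.2-fold higher number from compound 2 to compound 4 (0.34 log units; beyond the scatter) and so gives up part of the growth inhibition, and the whole acetylsulfamoyl group in place of hydrogen on the aromatic carbon gives a 2.2-fold higher number from compound 1 to compound 4 (0.33 log units; beyond the scatter) while the plain sulfamoyl group gave only a 1.0-fold lower number from compound 1 to compound 2 (0.00 log units; within the scatter) on the same kind of exchange. Nothing measured alongside these numbers accounts for any of the three new steps.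

The compounds shown leave open whether a fluoro, methoxy or trifluoromethyl group at this position would move the number as chloro does, and whether the chloro step holds where the sulfonamide nitrogen keeps its hydrogen. They also leave open how a propionyl or benzoyl group on that nitrogen would compare with acetyl.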